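The source may hold more compounds than are shown below. What is called first, only, known or untested is meant among the compounds shown, and "the series" means these compounds.

Working notes on the imine series. In an ADME assay on HepG2 cells (Homo sapiens) for cytotoxicity, read by MTT assay, with a stated time of 72 h (a lower number here means that less compound is tolerated, a higher number that more compound is tolerated), compound 1 `Clc1ccc(/C=N/c2sc3c(c2-c2nc4ccccc4s2)CCC3)cc1` gives 431 ug/mL. In this assay, within the data shown here, compound 2 `Clc1ccccc1/C=N/c1sc2c(c1-c1nc3ccccc3s1)CCC2` gives 180 ug/mL; the single change from compound 1 to compound 2 produced a 2.4-fold lower number from compound 1 to compound 2 (0.38 log units; beyond the scatter). In this assay compound 3 `Fc1ccc(/C=N/c2sc3c(c2-c2nc4ccccc4s2)CCCC3)cc1` gives 324 ug/mL, the second highest of the three numbers; its gaps to compound 1 and to compound 2 both lie within the scatter, so no order among these three can be read from them. Compound 4 `Clc1ccccc1/C=N/c1sc2c(c1-c1nc3ccccc3s1)CCCC2` has not been measured. It differs from compound 3 in one place: 2-chlorophenyl in place of 4-fluorophenyl on a carbon with a double bond to nitrogen. Among the measured compounds shown here, only one measured step bears on this change, the exchange of 4-chlorophenyl for 2-chlorophenyl from compound 1 to compound 2, a modest step beyond the scatter; compound 3 carries 4-fluorophenyl rather than 4-chlorophenyl and a different core, so the transfer is imperfect. A modest downward step is expected in this assay, namely a 2.0-fold lower number from compound 3 to compound 4 (0.31 log units; beyond the scatter). Compound 4 is therefore estimated at 160 ug/mL, with a range from 80 ug/mL to 320 ug/mL.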

Compound 4, half-maximal cytotoxic concentration: 370 ug/mL
Beside the measured number, compound 4's estimate is 2.3-fold (0.36 log units) below it, and the stated range ends below it.
By their numbers in this assay, from the lowest: compounds 2, 3, 4 and 1 (each within the scatter of the next, the first and the last beyond it).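

In this assay the exchange of 4-fluorophenyl for 2-chlorophenyl on a carbon with a double bond to nitrogen gives a 1.1-fold higher number from compound 3 to compound 4 (0.06 log units; within the scatter) and so leaves no readable change on the core of compound 3. A 2-chlorophenyl group at this place therefore does not bring a lower number in every case: a 2.4-fold lower number from compound 1 to compound 2 (0.38 log units; beyond the scatter) stands beyond the scatter on the core of compound 1, but that step starts from a different group on a different core. Nothing measured here explains why the two steps differ.

Still open, as far as these compounds go, is whether the core or the group that leaves decides the size of the step. Also open, from the compounds shown here alone, is how a phenyl group carrying an amine or a carboxylic acid would read at this place.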